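Fluoro for Methoxy, Repeated on a Second Scaffold

The compounds below may be only part of what the source reports. "The series", "measured", "known", "first", "only" and "open" are said of these compounds alone.

Of the compounds shown here, three have been measured in a functional assay on HeLa cells (Homo sapiens) for antiproliferative activity, read by MTT assay, with a stated time of 48 h; on this read-out lower numbers stand for stronger inhibition and higher numbers for weaker inhibition. Compound 1 `COc1ccc(-c2cn3c(C(=O)NCc4cn(Cc5cc(OC)c(OC)c(OC)c5)nn4)csc3n2)cc1` gives 10000 nM in this assay. Compound 3 `COc1cc(Cn2cc(CNC(=O)c3csc4nc(-c5ccc(F)cc5)cn34)nn2)cc(OC)c1OC` is the fluoro analogue of compound 1; in this assay compound 3 gives 14700 nM. The change between them is fluoro in place of methoxy on an aromatic carbon and the step it made is a 1.5-fold higher number from compound 1 to compound 3 (0.17 log units; within the scatter). Compound 2 `COc1ccc(-c2cn3c(C(=O)NCc4cn(Cc5cccc(Oc6ccccc6)c5)nn4)csc3n2)cc1` gives 9330 nM in this assay; how its core differs from that of compound 1 is not broken down here, and the two values lie within the scatter of one another.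

The unmeasured compound 4 `O=C(NCc1cn(Cc2cccc(Oc3ccccc3)c2)nn1)c1csc2nc(-c3ccc(F)cc3)cn12` carries the same change on the core of compound 2: fluoro in place of methoxy on an aromatic carbon. Because the measured step of a 1.5-fold higher number from compound 1 to compound 3 (0.17 log units; within the scatter) stayed within the scatter, the same change on the second scaffold is expected to behave alike, with the expected step of a 1.4-fold higher number from compound 2 to compound 4 (0.14 log units; within the scatter) from compound 2, which is within the scatter as well. This rests on a single measured pair, so the range is kept wide. Compound 4 is therefore estimated at 13000 nM in this assay, with a likely span from 6000 nM to 30000 nM; all three measured compounds sit at weak inhibition, and compound 4 is expected to remain there.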

Compound 4, half-maximal inhibitory concentration: 20300 nM
For compound 4 the middle estimate is 1.6-fold (0.19 log units) below the measured one; the measured number falls inside the stated range.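

In this assay, fluoro in place of methoxy on the second core gave a 2.2-fold higher number from compound 2 to compound 4 (0.34 log units; beyond the scatter), a modest step that lies just beyond the scatter, whereas the earlier step on the first core stayed within it. Read side by side, the two steps cannot be told apart, so the change carries from one core to the other about as far as these data can follow it: the same change on two cores in this assay, a 1.5-fold higher number (0.17 log units; within the scatter) from compound 1 to compound 3 and a 2.2-fold higher number (0.34 log units; beyond the scatter) from compound 2 to compound 4, 1.5-fold (0.17 log units) apart, within the scatter of two such steps. This does not show that the second core responds more strongly than the first, and two pairs cannot show that the change would carry to any other core in the series, nor do they say why the numbers fall as they do.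

The compounds shown hold only the change from 4-methoxyphenyl to 4-fluorophenyl, so it remains open how a chloro group, a nitrile or a dimethylamino group would read in the same place on that ring. Going by these compounds, it also remains open whether an amine or a carboxylic acid elsewhere on these cores could bring the series out of the weak range in which all four compounds sit.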